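Phenoxy replacement on the fused pyrrolidine series: compound 3

A few compounds are considered here, and "the series" means these few. Any claim that something is new, unique, unknown or untested is made for them only; others in the source may bear on it.

Measured so far:
compound 1, `Cn1c(CN2C[C@@H]3C(COc4cccc(-c5ccccc5)c4)[C@@H]3C2)nc2ccccc21` — 113 nM
compound 2, `Cn1c(CN2C[C@@H]3C(COc4cc(F)ccc4F)[C@@H]3C2)nc2ccccc21` — 7 nM

Two compounds of the shared core have been run in an in vitro assay on HEK293 cells with metabotropic glutamate receptor 2 (Rattus norvegicus) as the target, read by FLIPR, in the presence of a further agent that is not named here; on this read-out higher numbers stand for an effect only at larger amounts of compound and lower numbers for an effect already at smaller amounts. Compound 1 gives 113 nM. Compound 2 gives 7 nM, the lowest of the two numbers, and the gap to compound 1 lies beyond the usual scatter. For the measured compounds named here, no pair differing in a single place has been measured, so no step of known size exists in this set.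

Compound 3, `Cn1c(CN2C[C@@H]3C(COc4ccc(Cl)cc4)[C@@H]3C2)nc2ccccc21`, is not yet measured. Its difference from compound 2 is 4-chlorophenyl in place of 2,5-difluorophenyl on an oxygen on a saturated carbon, in words: 4-chlorophenyl in place of 2,5-difluorophenyl on an oxygen on a saturated carbon. Compound 1 shows that a larger change on this phenoxy group moves the number of this assay considerably, but nothing measured tells how a halogen pattern swap on the ring alone behaves.

For compound 3 a modest move toward higher numbers is expected, a 2.9-fold higher number from compound 2 to compound 3 (0.46 log units; beyond the scatter), since compound 2 carries the lowest value seen and a change at that place is more likely to cost than to gain. Compound 3 is estimated at 20 nM, with a range from 5 nM to 80 nM.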

Compound 3, half-maximal effective concentration: 26 nM
Compound 3: middle estimate off by 1.3-fold (0.11 log units), on the low side, and the stated range covers the measured number.
By their numbers in this assay, from the lowest: compound 2; then compound 3; then compound 1.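

In this assay, for the compounds shown here, the replacement of 2,5-difluorophenyl by 4-chlorophenyl on the oxygen gives the first single-place step: a 3.7-fold higher number from compound 2 to compound 3 (0.57 log units; beyond the scatter). A halogen swap on the ring, with the six-membered aromatic ring itself kept, is therefore enough to move the number beyond the usual scatter, although the step is only modest and compound 3 still reads 26 nM in this series. Nothing available bears on what lies behind this step.

The step changes the number of halogens, their kind and their places on the ring all at once, so the compounds shown cannot assign it to any one of these. Unsubstituted phenyl on the same oxygen would give a reference for both halogen patterns, while a nitrile or a methoxy group on the ring would show whether this position responds only to halogens or also to other groups.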